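The compounds below may be only part of what the source reports. "The series", "measured", "known", "first", "only" and "open" are said of these compounds alone.

Measured so far in a functional assay on HT-29 cells (Homo sapiens) for cytotoxicity, read by MTT assay, with a stated time of 72 h; on this read-out lower numbers stand for higher toxicity in this test and higher numbers for lower toxicity in this test:
Compound 1 `COc1ccc(CNc2nc([SeH])nc3ccccc23)cc1` gives > 100000 nM, a limit of the assay.
Compound 2 `CSc1ccc(CNc2nc([SeH])nc3ccccc23)cc1` gives > 100000 nM, a limit of the assay.
Compound 3 `[SeH]c1nc(NCc2ccccc2)c2ccccc2n1` gives > 100000 nM, a limit of the assay.

Compound 2 stands at the limit, and so do the other two; (the limit of > 100000 nM in this assay, at which 3 of the 3 values shown sit). Its value in this assay is a limit and not a number, so nothing places it above or below compound 1 or compound 3. The step to compound 4 `CSc1ccc(CNc2nc([Se]C)nc3ccccc23)cc1` is methyl in place of hydrogen on a selenium: the hydrogen on the selenium leaves and a methyl enters. Among the measured compounds shown here, none of the measured steps touches the selenium. Those that exist, a step that the two limits leave unreadable from compound 1 to compound 2, a step that the two limits leave unreadable from compound 1 to compound 3 and a step that the two limits leave unreadable from compound 2 to compound 3, all run from one limit to another and give no size in either direction. For the measured compounds named here, the change on the selenium is thus unsupported by any readable step; what bears on it is only that every compound with the shared core and hydrogen on the selenium sits at the limit. The expectation for compound 4 in this assay is therefore no step beyond the scatter, an at least 1.2-fold lower number from compound 2 to compound 4 (0.09 log units; that floor lies within the scatter), with a high chance that only a limit is reported again. Compound 4 is estimated at 80000 nM, between 15000 nM and 300000 nM.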

Compound 4, concentration lethal to 50% of the cells: > 100000 nM
Compound 4 gave a limit, no number; the forecaster's own chance of this, stated with the estimate: 70%; at least 1.2-fold (0.09 log units) between middle value and limit.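

No step can be read from compound 2 to compound 4, methyl in place of hydrogen on a selenium, because both values in this assay are limits and not numbers: the limit of > 100000 nM in this assay, at which 4 of the 4 values shown sit.

The compounds shown leave open whether any change on the shared core gives a number in this assay, and how far apart compound 1, compound 2, compound 3 and compound 4 actually lie.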